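The compounds below may be only part of what the source reports. "The series", "measured", "known", "first", "only" and "open" are said of these compounds alone.

Working notes on the series. In an ADME assay on HEL cells (Homo sapiens) for cytotoxicity (on this read-out higher numbers stand for lower toxicity in this test and lower numbers for higher toxicity in this test), compound 1 `C/C(=N\NC(=O)COc1cccc2ccccc12)c1ccc(C#N)cc1Br` gives 12.7 ug/mL and compound 2 `C/C(=N\NC(=O)COc1cccc2ccccc12)c1ccccc1Br` gives 16.2 ug/mL. These two bromo-bearing compounds are separated by a 1.3-fold higher number from compound 1 to compound 2 (0.11 log units; within the scatter).

Compound 3 `C/C(=N\NC(=O)COc1cccc2ccccc12)c1ccc([N+](=O)[O-])cc1` gives > 100 ug/mL in this assay. That value is a limit of the assay and not a number. Compound 3 therefore stands at the limit of > 100 ug/mL in this assay, at which 1 of the 3 values shown sits, and only a bound on it is known.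

Compound 4 `C/C(=N\NC(=O)COc1cccc2ccccc12)c1ccc(Br)cc1` has bromo in place of nitro on an aromatic carbon, para to a large group (bromo in place of nitro on an aromatic carbon). Among the compounds with values here, two measured steps bear on this, both read in the opposite direction: an at least 7.8-fold higher number from compound 1 to compound 3 (0.89 log units; beyond the scatter) and an at least 6.1-fold higher number from compound 2 to compound 3 (0.79 log units; beyond the scatter). Neither is the same change, since they start from 2-bromo-4-cyanophenyl and 2-bromophenyl, not from 4-bromophenyl. They still suggest that losing the 4-nitrophenyl group lowers the number by a modest step beyond the scatter, though a smaller drop remains possible with the bromo placed differently.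

The expected change is an at least 3.3-fold lower number from compound 3 to compound 4 (0.52 log units; beyond the scatter). For compound 4 the estimated value is 30 ug/mL, with an expected range of 11 ug/mL to 100 ug/mL.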

Compound 4, half-maximal cytotoxic concentration: 15.3 ug/mL
Compound 4: middle estimate off by 2.0-fold (0.29 log units), on the high side; measured number inside the range.
By their numbers in this assay, from the lowest: compounds 1, 4 and 2 (each within the scatter of the next). At a limit, above all of these: compound 3.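

In this assay, the exchange of nitro for bromo on an aromatic carbon, para to a large group, now has a direct step: an at least 6.5-fold lower number from compound 3 to compound 4 (0.81 log units; beyond the scatter). The three bromo-bearing compounds stay together whether the aryl group is 4-bromophenyl, 2-bromophenyl or 2-bromo-4-cyanophenyl, as shown by a 1.1-fold lower number from compound 2 to compound 4 (0.02 log units; within the scatter) and a 1.2-fold higher number from compound 1 to compound 4 (0.08 log units; within the scatter), so among these compounds neither the place of the bromo nor the cyano group separates the numbers, and compound 3, the only one without bromo, stands apart. Compound 3 remains a limit of the assay and not a number, so the step to it is a bound and its full size stays unknown: the limit of > 100 ug/mL in this assay, at which 1 of the 4 values shown sits.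

The compounds shown cannot tell whether the high number of compound 3 belongs to the nitro group itself or simply to the absence of bromo. An amine, a methoxy group or a carboxylic acid at this same position, or a plain phenyl ring with hydrogen there, would separate these two readings.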